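A few compounds are considered here, and "the series" means these few. Any claim that something is new, unique, unknown or untested is made for them only; others in the source may bear on it.

Compound 2 `COc1c(N2CCN(CC(C)=O)C(C)C2)c(F)cc2c(=O)c(C(=O)O)cn(C3CC3)c12`, compound 3 `COc1c(N2CCN(C/C(C)=N/O)C(C)C2)c(F)cc2c(=O)c(C(=O)O)cn(C3CC3)c12` and compound 1 `CCOC(=O)CCN1CCN(c2c(F)cc3c(=O)c(C(=O)O)cn(C4CC4)c3c2OC)CC1C` share one core and differ only in the group on a saturated chain carbon bound to an amine nitrogen in a ring. In an ADME assay on Vero cells (Chlorocebus sabaeus) for cytotoxicity, read by MTT assay, with a stated time of 72 h (a lower number here means that less compound is tolerated, a higher number that more compound is tolerated), compound 2 gives 500 ug/mL, while compound 3 gives 177 ug/mL; in this assay compound 1 has the entry "not determined" (no result reported), so no number was reported for it. Of the two numbers in hand, compound 2 stands highest, and its nearest neighbour is compound 3, the step between them being a 2.8-fold lower number from compound 2 to compound 3 (0.45 log units; beyond the scatter), a modest one.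

Compound 4 `CCO/N=C(\C)CCN1CCN(c2c(F)cc3c(=O)c(C(=O)O)cn(C4CC4)c3c2OC)CC1C` has not yet been tested in this assay. It differs from compound 2 in a single place: a group of 7 heavy atoms (5 carbon, 1 nitrogen, 1 oxygen; no ring) in place of a group of 3 heavy atoms (2 carbon, 1 oxygen; no ring), on a saturated chain carbon bound to an amine nitrogen in a ring. Within the data shown here, the only measured step that bears on this change is the one from compound 2 to compound 3, in which an acetyl group was likewise replaced at the same position by a chain carrying a nitrogen and an oxygen, and that step lay beyond the scatter. Because the step from compound 2 to compound 3 was a 2.8-fold lower number from compound 2 to compound 3 (0.45 log units; beyond the scatter), and the change to compound 4 runs the same way with a larger entering group, a modest lowering is expected, roughly a 2.5-fold lower number from compound 2 to compound 4 (0.40 log units; beyond the scatter). Compound 4 is therefore estimated to give about 200 ug/mL, within a range from 70 ug/mL to 500 ug/mL.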

Compound 4, half-maximal cytotoxic concentration: 88.4 ug/mL
Beside the measured number, compound 4's estimate is 2.3-fold (0.35 log units) above it; low and high end bracket the measured number.
By their numbers in this assay, from the lowest: compounds 4 and 3 (each within the scatter of the next); then compound 2.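

In this assay, a second replacement of the acetyl group on a saturated chain carbon bound to an amine nitrogen in a ring also gives a lower number, a 5.7-fold lower number from compound 2 to compound 4 (0.75 log units; beyond the scatter), so the fall seen earlier with compound 3 is not confined to one entering group, and neither of the two replacements shown goes against this. The larger group adds little further, however: the step of a 2.0-fold lower number from compound 3 to compound 4 (0.30 log units; within the scatter) leaves the two entering groups unseparated, so this series gives no measured link between size and tolerated concentration once the acetyl group has left. No measured evidence here accounts for either step.

Any step to compound 1 cannot be read, as compound 1 has the entry "not determined" (no result reported), so the effect of its ester-bearing chain remains unknown. Also open, from the compounds shown here alone, is whether a plain longer alkyl chain, an amine or a carboxylic acid at this place would stay close to compound 2 or fall with compound 3 and compound 4.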